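The source may report more compounds than this note shows. Statements on the series, on what has been measured and on what is new or still open speak of the compounds shown alone.

Compound 1 `CC[C@H]1CC[C@H](c2ccc(NC(=S)Nc3cccc(C(F)(F)F)c3)cc2)CC1`: 10000 nM
Compound 2 `O=[N+]([O-])c1ccc(NC(=S)Nc2cccc(C(F)(F)F)c2)cc1`: 9500 nM
Compound 3 `Fc1ccc(NC(=S)Nc2cccc(C(F)(F)F)c2)cc1`: 26000 nM

In an ADME assay on BHK cells (Mesocricetus auratus) for cytotoxicity, read by MTT assay, with a stated time of 96 h (on this read-out higher numbers stand for lower toxicity in this test and lower numbers for higher toxicity in this test), compound 3 stands highest of the three at 26000 nM. Compound 4 `CCOC(=O)c1ccc(NC(=S)Nc2cccc(C(F)(F)F)c2)cc1` is still unmeasured and differs from compound 3 by ethoxycarbonyl in place of fluoro on an aromatic carbon. The two other groups measured at this place give modest steps of similar size, a 2.6-fold higher number from compound 1 to compound 3 (0.41 log units; beyond the scatter) and a 2.7-fold higher number from compound 2 to compound 3 (0.44 log units; beyond the scatter), while a 1.1-fold lower number from compound 1 to compound 2 (0.02 log units; within the scatter) stays within the scatter. A modest step to a lower number is therefore expected when ethoxycarbonyl replaces fluoro. The expected change is a 2.2-fold lower number from compound 3 to compound 4 (0.34 log units; beyond the scatter). Compound 4 is estimated at 12000 nM, with an expected range of 5500 nM to 26000 nM.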

Compound 4, half-maximal cytotoxic concentration: 50000 nM
Estimate against measurement, compound 4: 4.2-fold (0.62 log units) below; measured number above the stated range.
By their numbers in this assay, from the lowest: compounds 2 and 1 (each within the scatter of the next); then compounds 3 and 4 (each within the scatter of the next).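

In this assay, ethoxycarbonyl in place of fluoro does not separate the two groups at this position, with a 1.9-fold higher number from compound 3 to compound 4 (0.28 log units; within the scatter). The same ethoxycarbonyl stands clear of the other two groups, with a 5.3-fold higher number from compound 2 to compound 4 (0.72 log units; beyond the scatter) and a 5.0-fold higher number from compound 1 to compound 4 (0.70 log units; beyond the scatter), so the four compounds fall into two sets: compound 3 with compound 4, and compound 1 with compound 2. No measurement shown accounts for this split.

Going by these compounds, whether a carboxylic acid or an amine at this position would fall with compound 3 and compound 4 or with compound 1 and compound 2 remains open. On these data alone, the effect of a longer ester chain also remains open.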